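Swapping Fluoro for Chloro on Compound 2

The source may report more compounds than this note shows. Statements on the series, on what has been measured and on what is new or still open speak of the compounds shown alone.

In a functional assay on thoracic aorta (Rattus norvegicus, strain Wistar), with a stated time of 15 min (a higher number here means that more compound is needed for the effect, a lower number that less compound is needed), compound 2 `COc1ccc(F)cc1C(C)NC(=O)N(C)S(=O)(=O)c1ccc(Cl)cc1` gives 12600 nM, the lower of the two actual numbers available. In the same test, compound 3 `CC(NC(=O)NS(=O)(=O)c1ccc(Cl)cc1)c1cc(Br)ccc1OCc1ccccc1` gives 57500 nM, and its gap from compound 2 lies beyond the usual scatter. For compound 1 `CCOc1ccc(Cl)cc1C(C)NC(=O)NS(=O)(=O)c1ccc(C)cc1`, the result > 300000 nM is only a limit of this assay, not a measured number.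

The next molecule, compound 4 `COc1ccc(Cl)cc1C(C)NC(=O)N(C)S(=O)(=O)c1ccc(Cl)cc1`, differs from compound 2 at a single place (chloro in place of fluoro on an aromatic carbon). It carries chloro in place of fluoro on an aromatic carbon, para to a methoxy group. Among the compounds with values here, no measured pair here shows this swap on its own, and the three measured compounds differ from each other in several places. The expectation therefore rests on compound 2 at 12600 nM and on the change being confined to one place. The estimated step of a 1.1-fold lower number from compound 2 to compound 4 (0.06 log units; within the scatter) is expected to stay within the usual scatter, with no clear direction. For compound 4, the expected value is 11000 nM, with an estimated range of 3500 nM to 40000 nM.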

Compound 4, half-maximal effective concentration: 20000 nM
For compound 4 the middle estimate is 1.8-fold (0.26 log units) below the measured one; the measured number falls inside the stated range.
By their numbers in this assay, from the lowest: compounds 2 and 4 (each within the scatter of the next); then compound 3. At a limit, above all of these: compound 1.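

With chloro in place of fluoro on this aromatic carbon, para to a methoxy group, this assay shows a 1.6-fold higher number from compound 2 to compound 4 (0.20 log units; within the scatter), and this is the only pair shown in which a single change stands alone. At this position, then, the two groups cannot be told apart in this test, and no direction can be claimed for the swap. Nothing measured here offers an explanation for this outcome.

As far as these compounds go, whether an amine, a carboxylic acid or a nitrile on the same aromatic carbon would shift the number beyond the usual scatter remains open. From the compounds shown here alone, it also remains open whether the same swap would give a similar result on compound 3, which differs from compound 2 in several places.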